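What a bromo group may do to compound 3

The source may hold more compounds than are shown below. What is called first, only, known or untested is meant among the compounds shown, and "the series" means these compounds.

Measured so far in an ADME assay on L6 cells (Rattus norvegicus) for cytotoxicity, read by resazurin assay, with a stated time of 72 h; on this read-out higher numbers stand for weaker inhibition and lower numbers for stronger inhibition
- compound 1 `CC(=O)OC[C@H]1O[C@@H](N2C(=O)/C(=C3/C(=O)Nc4ccc(I)cc43)c3ccccc32)[C@H](OC(C)=O)[C@@H](OC(C)=O)[C@@H]1OC(C)=O` gives 11300 nM
- compound 2 `CC(=O)OC[C@H]1O[C@@H](N2C(=O)/C(=C3/C(=O)Nc4ccc(Cl)cc43)c3ccccc32)[C@H](OC(C)=O)[C@@H](OC(C)=O)[C@@H]1OC(C)=O` gives 13700 nM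
- compound 3 `CCCC(=O)c1ccc2c(c1)/C(=C1\C(=O)N([C@@H]3O[C@H](COC(C)=O)[C@@H](OC(C)=O)[C@H](OC(C)=O)[C@H]3OC(C)=O)c3ccccc31)C(=O)N2` gives 31700 nM

Compound 3 stands highest of the three, so it is the weakest inhibitor here. Compound 4 `CCCC(=O)c1ccc2c(c1)/C(=C1\C(=O)N([C@@H]3O[C@H](COC(C)=O)[C@@H](OC(C)=O)[C@H](OC(C)=O)[C@H]3OC(C)=O)c3ccc(Br)cc31)C(=O)N2` is compound 3 with bromo in place of hydrogen on an aromatic carbon and no other change.

Within the data shown here, no measured step replaces a hydrogen, so the evidence is indirect. Chloro in place of iodo gave a 1.2-fold higher number from compound 1 to compound 2 (0.08 log units; within the scatter) and so shows no real difference between those two halogens. Propylcarbonyl in place of a halogen gave a 2.8-fold higher number from compound 1 to compound 3 (0.45 log units; beyond the scatter) and a 2.3-fold higher number from compound 2 to compound 3 (0.36 log units; beyond the scatter) and both are modest. Compound 4 keeps the propylcarbonyl and gains a halogen, so only a small move toward a lower number in this assay is expected, perhaps none beyond the scatter. The estimated change is a 1.4-fold lower number from compound 3 to compound 4 (0.16 log units; within the scatter) and it remains uncertain. The expected value for compound 4 is 22000 nM within an estimated range of 8000 nM to 50000 nM for this prediction.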

Compound 4, half-maximal inhibitory concentration: 99000 nM
The estimate for compound 4 lay 4.5-fold (0.65 log units) below the measured number, and the stated range ends below it.
By their numbers in this assay, from the lowest: compounds 1 and 2 (each within the scatter of the next); then compound 3; then compound 4.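

Among these compounds, this is the first step in the set that replaces a hydrogen rather than swapping one group for another, so it gives the first direct reading of adding a group at this place. In this assay, bromo on this aromatic carbon gives a 3.1-fold higher number from compound 3 to compound 4 (0.49 log units; beyond the scatter), a modest change beyond the scatter toward weaker inhibition of the cells. The earlier exchange between chloro and iodo could not show this, and no measurement available here explains the rise.

From the compounds shown here alone, it remains open whether the rise belongs to bromo itself or would also appear with another group at this place, such as methyl or an amine. Going by these compounds, it is also open whether bromo here would raise the number to the same extent with chloro or iodo in place of the propylcarbonyl.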